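The source may hold more compounds than are shown below. What is called first, only, known or untested is meant among the compounds shown, and "the series" means these compounds.

Compound 3 `COc1cccc(OCc2cc(C)nc(-c3ccccn3)n2)c1` gives the highest of the three numbers in a functional assay on cells for antagonist activity at Free fatty acid receptor 1 (Homo sapiens), read by TR-FRET and inositol phosphate accumulation, with a stated time of 2 h (on this read-out higher numbers stand for weaker inhibition and lower numbers for stronger inhibition), at 2000 nM. Its nearest neighbour is compound 1 `Cc1cc(COc2ccccc2)nc(-c2ccccn2)n1`, which gives 794 nM; that gap is a 2.5-fold higher number from compound 1 to compound 3 (0.40 log units; beyond the scatter). Compound 2 `Cc1cc(COc2cccc(Cl)c2)nc(-c2ccccn2)n1` gives 398 nM, and a 5.0-fold higher number from compound 2 to compound 3 (0.70 log units; beyond the scatter). Between compounds 1 and 2 the step is a 2.0-fold lower number from compound 1 to compound 2 (0.30 log units; within the scatter). Compound 4 `Cc1cc(COc2cccc(C#N)c2)nc(-c2ccccn2)n1` arises from compound 3 by cyano in place of methoxy on an aromatic carbon. Both steps that bear on it, the methoxy in place of hydrogen and the methoxy in place of chloro, made the number worse, so removing methoxy is expected to recover some of that loss. Compound 4 is therefore expected to give about 600 nM, with a range from 250 nM to 1500 nM. That estimate means a step of a 3.3-fold lower number from compound 3 to compound 4 (0.52 log units; beyond the scatter).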

Compound 4, half-maximal inhibitory concentration: 2510 nM
Compound 4: the middle estimate sits 4.2-fold (0.62 log units) below what was measured; measured number above the stated range.
By their numbers in this assay, from the lowest: compounds 2 and 1 (each within the scatter of the next); then compounds 3 and 4 (each within the scatter of the next).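

In this assay, cyano on this aromatic carbon, meta to a large group, recovers nothing of what methoxy lost: a 1.3-fold higher number from compound 3 to compound 4 (0.10 log units; within the scatter) shows the two groups within the scatter of each other. Cyano also lies clearly higher than the other two groups, with a 3.2-fold higher number from compound 1 to compound 4 (0.50 log units; beyond the scatter) against hydrogen and a 6.3-fold higher number from compound 2 to compound 4 (0.80 log units; beyond the scatter) against chloro, so the loss is not confined to methoxy. No evidence is given that accounts for this difference among the groups.

The compounds shown leave open whether an amine or a carboxylic acid here would fall with hydrogen and chloro or with methoxy and cyano.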